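The source may hold more compounds than are shown below. What is called first, only, known or untested is meant among the compounds shown, and "the series" means these compounds.

Measured so far in an ADME assay on L02 cells (Homo sapiens) for antiproliferative activity, read by MTT assay, with a stated time of 48 h; a higher number here means a weaker inhibitor, a lower number a stronger inhibitor; every value in this list is a limit of the assay, not a number:
compound 1 `N#CC1=C(N)Oc2c(c3nc4ccccc4nc3c3ccccc23)C12C(=O)N(Cc1cnnn1-c1ccc([N+](=O)[O-])cc1)c1ccccc12` — > 50000 nM
compound 2 `N#CC1=C(N)Oc2c(c3nc4ccccc4nc3c3ccccc23)C12C(=O)N(Cc1cnnn1-c1ccc(S(N)(=O)=O)cc1)c1ccccc12` — > 50000 nM
compound 3 `N#CC1=C(N)Oc2c(N)cc3nc4ccccc4nc3c2C12C(=O)N(Cc1cnnn1-c1ccc(F)cc1)c1ccccc12` — > 50000 nM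

Compound 3 stands at the limit given by the limit of > 50000 nM in this assay, at which 3 of the 3 values shown sit, so no numerical reading places it relative to the other two, and nothing in the set orders any compound against another. Among the measured compounds shown here, the single step read, a step that the two limits leave unreadable from compound 1 to compound 2, runs from one limit to another and its size cannot be taken from the data.

Compound 4 `N#CC1=C(N)Oc2c(N)cc3nc4ccccc4nc3c2C12C(=O)N(Cc1cnnn1-c1ccc([N+](=O)[O-])cc1[N+](=O)[O-])c1ccccc12` differs from compound 3 by 2,4-dinitrophenyl in place of 4-fluorophenyl on an aromatic nitrogen. For the measured compounds named here, no measured step bears on this particular change: the one step available is unreadable, and the limit of > 50000 nM in this assay, at which 3 of the 3 values shown sit, is where every value shown sits. Going by the values given here, the change on the aromatic nitrogen of the five-membered ring is the only variable between compound 3 and compound 4, and the shared core is kept.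

The expected step that the limit leaves unreadable from compound 3 to compound 4 is therefore set within the scatter, in no direction. Compound 4 is expected most likely to return a limit again rather than a number. Compound 4 is estimated at 60000 nM, with a range from 20000 nM to 200000 nM.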

Compound 4, half-maximal inhibitory concentration: 22800 nM
Compound 4: middle estimate off by 2.6-fold (0.42 log units), on the high side; low and high end bracket the measured number.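

In this assay, among the compounds shown here, the aromatic nitrogen of the five-membered ring proves to be a place where the read-out can be moved: with the shared core kept, 2,4-dinitrophenyl in place of 4-fluorophenyl gives an at least 2.1-fold lower number from compound 3 to compound 4 (0.34 log units; beyond the scatter), the only readable step. The value of compound 3, > 50000 nM, is a limit and not a number, so this step fixes only a minimum size. Compound 4 is the only compound shown to give a number in this assay, while the others remain at the limit: the limit of > 50000 nM in this assay, at which 3 of the 4 values shown sit.

The step from compound 1 to compound 2 runs between two limits and cannot be read, which leaves the sulfamoyl and nitro groups unordered on that core. On these data alone, the step from compound 3 to compound 4 exchanges the whole aryl group, so it remains open whether both nitro groups are needed, and how a phenyl ring carrying a single nitro group, an amine or a carboxylic acid would read on the core of compound 3.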